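This account rests on a few compounds, and the source may have more. Where it says the series, first, only, none or still open, it means among the compounds named here.

Measured so far in a functional assay on M14 cells (Homo sapiens) for inhibition, read by sulforhodamine B assay, with a stated time of 48 h; on this read-out higher numbers stand for weaker inhibition of growth and lower numbers for stronger inhibition of growth:

compound 1, `COc1cc(-c2nn(-c3cccc(NC(=O)Nc4cc(C(F)(F)F)cc(C(F)(F)F)c4)c3)cc2-c2ccncc2)ccc1Cl` — compound 1 gives 2550 nM
compound 3, `O=C(Nc1cccc(-n2cc(-c3ccncc3)c(-c3ccc(Cl)c(O)c3)n2)c1)Nc1cc(C(F)(F)F)cc(C(F)(F)F)c1` — compound 3 gives 1810 nM
compound 2, `COc1cc(-c2nn(-c3cccc(NC(=O)c4cccc(C(F)(F)F)c4)c3)cc2-c2ccncc2)ccc1Cl` — compound 2 gives only a limit of the assay, > 50000 nM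

Among the compounds with values here, the single measured step is a 1.4-fold lower number from compound 1 to compound 3 (0.15 log units; within the scatter), a change of the methoxy to a hydroxyl that leaves the number where it was. Within the data shown here, compound 2 is the one compound of the three that returns a limit rather than a number (the limit of > 50000 nM in this assay, at which 1 of the 3 values shown sits), so its true value is unknown beyond that bound, and no step can be computed from it.

Compound 4, `COc1cc(-c2nn(-c3cccc(NC(=O)Nc4ccc(Cl)c(C(F)(F)F)c4)c3)cc2-c2ccncc2)ccc1Cl`, differs from compound 2 by (4-chloro-3-(trifluoromethyl)phenyl)amino in place of 3-(trifluoromethyl)phenyl on a carbonyl carbon. This turns the amide of compound 2 into a urea of the kind carried by compound 1 and compound 3, with a chloro and trifluoromethyl pattern on the outer ring that is not matched elsewhere in the set. Among the measured compounds shown here, no measured step covers this change; the only bearing is that the two ureas, compound 1 and compound 3, sit at measurable numbers while the amide, compound 2, sits at the limit. The expectation for compound 4 is therefore a step out of the limit region, an at least 20-fold lower number from compound 2 to compound 4 (1.30 log units; beyond the scatter), toward the values of the ureas. Compound 4 is estimated at 2500 nM in this assay, with a range of 700 nM to 9000 nM.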

Compound 4, concentration for total growth inhibition: 3710 nM
Compound 4: the middle estimate sits 1.5-fold (0.17 log units) below what was measured; the measured number falls inside the stated range.
By their numbers in this assay, from the lowest: compounds 3, 1 and 4 (each within the scatter of the next, the first and the last beyond it). At a limit, above all of these: compound 2.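

In this assay compound 2 stands at a limit of the assay and not at a number: the limit of > 50000 nM in this assay, at which 1 of the 4 values shown sits.

The change on the carbonyl carbon gives an at least 13-fold lower number from compound 2 to compound 4 (1.12 log units; beyond the scatter), a step out of that limit, but the amino link and the chlorine on the outer ring enter together, so this step alone does not separate their shares. In this assay compound 1 gives 2550 nM and compound 4 gives 3710 nM, two values within the scatter of each other, so the urea keeps its level with this second outer ring.

Open, on these data alone, is how an amide carrying the 4-chloro-3-(trifluoromethyl)phenyl group and a urea carrying the 3-(trifluoromethyl)phenyl group would read, the two compounds that would divide the step between the amino link and the chlorine. Also open is whether the link tolerates anything other than the amide and urea shown, such as a carbamate or a sulfonamide, and whether the outer ring can carry a morpholine or a carboxylic acid in place of its chloro or trifluoromethyl groups.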